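This account rests on a few compounds, and the source may have more. Where it says the series, first, only, none or still open, it means among the compounds named here.

Among the measured compounds shown here, compound 2 `COc1cc2c(cc1OC)C(CC(=O)N1CCNCC1)CC2` gives the higher of the two numbers measured so far: in a functional assay on the whole organism (strain Swiss albino) for inhibition, with Mus musculus as the target, in the writhing test, with stated times of 60 min and 15 min, at a dose of 100 mg/kg by the oral route (on this read-out lower numbers stand for less inhibition and higher numbers for more inhibition at the one dose given (going by the name of the read-out)), compound 2 gives 68.8%, while compound 1 `CCCCNC(=O)CC1CCc2cc(OC)c(OC)cc21` gives 39.4%. For the measured compounds named here, the one measured step, a number 29.4 percentage points higher from compound 1 to compound 2 (beyond the scatter), shows that the group on the carbonyl carbon can move the read-out. Compound 3 `COc1cc2c(cc1OC)C(CC(=O)NCCO)CC2` carries a different change at that carbon: (2-hydroxyethyl)amino in place of piperazin-1-yl on a carbonyl carbon. Going by the values given here, no measured step matches this change, so the direction is uncertain. Among the compounds with values here, a modest drop is expected for compound 3 in this assay, namely a number 16.8 percentage points lower from compound 2 to compound 3 (beyond the scatter), because the only known step of a number 29.4 percentage points higher from compound 1 to compound 2 (beyond the scatter) was itself modest. Compound 3 is expected to give 52%, within 32% to 72%.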

Compound 3, a percentage reported as inhibition, in the whole organism at one dose (the size of the read-out at that dose, not a potency): 29.8%
Estimate against measurement, compound 3: 22.2 percentage points above, and the stated range ends above it.
By their numbers in this assay, from the lowest: compounds 3 and 1 (each within the scatter of the next); then compound 2.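

In this assay, replacing piperazin-1-yl with (2-hydroxyethyl)amino on the carbonyl carbon gives a number 39 percentage points lower from compound 2 to compound 3 (beyond the scatter), so compound 2 now stands clear of two compounds that lack its ring. Hydroxy in place of ethyl on the saturated chain carbon gives a number 9.6 percentage points lower from compound 1 to compound 3 (within the scatter), so this exchange on the chain cannot be told from no change. No available evidence explains these results. As far as these compounds go, whether the ring or its second nitrogen matters remains open. Piperidin-1-yl or morpholin-4-yl on the same carbonyl carbon would help separate the two.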